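The source may hold more compounds than are shown below. What is called first, only, known or untested is meant among the compounds shown, and "the series" means these compounds.

Measured in a functional assay (aorta) with Rattus norvegicus as the target; a lower number here means a stronger inhibitor, a higher number a weaker inhibitor:
compound 1 `CC1(C)Oc2ccc(C#N)cc2[C@@H](/N=C(\NC#N)Nc2ccccc2)[C@@H]1O`: 1400 nM; 1300 nM (2 entries)
compound 2 `CC1(C)Oc2ccc(C#N)cc2[C@@H](/N=C(\NC#N)Sc2ccccc2)[C@@H]1O`: 4900 nM
compound 3 `CC1(C)Oc2ccc(C#N)cc2[C@@H](NC(=O)NCc2ccccc2)[C@@H]1O`: 5600 nM

Compound 3 gives 5600 nM, and this lies within the scatter of compound 2 at 4900 nM. Compound 1 gives a lower number than either, 1400 nM; 1300 nM (2 entries), and its repeat entries agree: the several entries of compound 1 in this assay, 1400 nM; 1300 nM (2 entries).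

The next step leads from compound 3 to compound 4 `CC1(C)Oc2ccc(C#N)cc2[C@@H](NC(=O)Nc2ccncc2)[C@@H]1O`: pyridin-4-yl in place of benzyl on an amide-type nitrogen. In words, pyridin-4-yl stands in place of benzyl on an amide-type nitrogen. Going by the values given here, no step between measured compounds that differ in one place is available, so the likely size of the change in this assay can only be judged from the spread of the three values. Compound 1 carries no benzyl group and gives 1400 nM; 1300 nM (2 entries), but it differs from compound 4 in more than one place, so this supports only a modest expectation of a lower number. The expected move is a 2.2-fold lower number from compound 3 to compound 4 (0.35 log units; beyond the scatter), and the direction is not firm. For compound 4 the estimated value is 2500 nM, with an expected range of 500 nM to 10000 nM.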

Compound 4, half-maximal inhibitory concentration: 8500 nM
For compound 4 the middle estimate is 3.4-fold (0.53 log units) below the measured one; the measured number falls inside the stated range.
By their numbers in this assay, from the lowest: compounds 2, 3 and 4 (each within the scatter of the next).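

In this assay, going by these compounds alone, the exchange on the amide-type nitrogen gives a 1.5-fold higher number from compound 3 to compound 4 (0.18 log units; within the scatter), the only step so far that differs in one place. This position therefore accepts pyridin-4-yl in place of benzyl with no change beyond the scatter, even though the entering group brings a ring hetero atom and a hydrogen-bond acceptor that benzyl lacks, and the step gives no sign that either feature matters in this assay. Nothing measured here bears on the reason for this outcome.

Within the data shown here, the single step alters the ring and the link to the amide-type nitrogen together, so the contribution of each stays unresolved, and phenyl or pyridin-3-yl on this nitrogen would be needed to pull them apart. Also open, on these data alone, is how this position responds to groups of a different kind, such as a 2-phenylethyl chain, a piperidin-4-yl amine or a benzyl group carrying a carboxylic acid, since the two groups compared here are both single aromatic rings and span only a narrow range.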